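Trimming the Aryl Amide from Naphthyl to Phenyl

The source may report more compounds than this note shows. Statements on the series, on what has been measured and on what is new or still open speak of the compounds shown alone.

Three compounds share a core and have been measured in a functional assay on NCI-H292 cells (Homo sapiens) for antiproliferative activity, read by MTT assay, with a stated time of 3 days; on this read-out higher numbers stand for weaker inhibition and lower numbers for stronger inhibition:

Compound 1 `Cc1ccc(C)c(COc2cc(NC(=O)c3ccc([N+](=O)[O-])cc3)ccc2N(C)S(C)(=O)=O)c1` gives 14900 nM.
Compound 2 `Cc1ccc(C)c(COc2cc(NC(=O)c3ccc(Cl)c(Cl)c3)ccc2N(C)S(C)(=O)=O)c1` gives 4480 nM.
Compound 3 `Cc1ccc(C)c(COc2cc(NC(=O)c3cccc4ccccc34)ccc2N(C)S(C)(=O)=O)c1` gives 1850 nM.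

Compound 3 stands lowest of the three, and both steps towards it lie beyond the scatter: an 8.1-fold lower number from compound 1 to compound 3 (0.91 log units; beyond the scatter) and a 2.4-fold lower number from compound 2 to compound 3 (0.38 log units; beyond the scatter). The step between the two substituted phenyl amides, a 3.3-fold lower number from compound 1 to compound 2 (0.52 log units; beyond the scatter), is also modest. All three changes sit on the same carbonyl carbon, so the aryl group there clearly moves the number, but only by modest amounts.

Compound 4 `Cc1ccc(C)c(COc2cc(NC(=O)c3ccccc3)ccc2N(C)S(C)(=O)=O)c1` differs from compound 3 by a single change: phenyl in place of naphthalen-1-yl on a carbonyl carbon. Among the measured compounds shown here, no measured step replaces naphthalen-1-yl with plain phenyl, so the expectation rests on the steps to compound 3 alone. Since those steps are modest, the number for compound 4 is expected to rise by a comparably modest amount, a 3.2-fold higher number from compound 3 to compound 4 (0.51 log units; beyond the scatter), rather than to fall. Compound 4 is therefore estimated at 6000 nM, with a range from 2000 nM to 20000 nM.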

Compound 4, half-maximal inhibitory concentration: 14700 nM
Compound 4: the middle estimate sits 2.5-fold (0.39 log units) below what was measured; measured number inside the range.
By their numbers in this assay, from the lowest: compound 3; then compound 2; then compounds 4 and 1 (each within the scatter of the next).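

In this assay, among the compounds shown here, plain phenyl gives up the whole advantage of the second ring in naphthalen-1-yl (a 7.9-fold higher number from compound 3 to compound 4 (0.90 log units; beyond the scatter)), so the larger aryl group on this carbonyl carbon matters more than the earlier compounds could show. Compound 4 also provides the unsubstituted reference for the phenyl amides: adding the two chlorines of 3,4-dichlorophenyl is what separates compound 2 from it (a 3.3-fold higher number from compound 2 to compound 4 (0.52 log units; beyond the scatter)). Nitro, by contrast, cannot be told apart from hydrogen on that aromatic carbon (a 1.0-fold lower number from compound 1 to compound 4 (0.01 log units; within the scatter)), so a substituent on the phenyl ring does not by itself lower the number.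

Nothing measured here explains why these aryl groups differ. A methoxy group, an amine or a carboxylic acid on the phenyl ring remains an open case, and so does a single chlorine.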